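Swapping Furan for Thiophene on a Shared Core

This account rests on a few compounds, and the source may have more. Where it says the series, first, only, none or still open, it means among the compounds named here.

Measured compounds:
compound 1 `N#Cc1c(-c2ccco2)nc2c(c(-c3ccccc3)nn2-c2ccccc2)c1-c1ccc(O)cc1` 4200 nM
compound 2 `COc1cc(-c2c(C#N)c(-c3ccco3)nc3c2c(-c2ccccc2)nn3-c2ccccc2)ccc1O` 24900 nM

In a functional assay on K562 cells (Homo sapiens) for antiproliferative activity, read by resazurin assay, with a stated time of 72 h (a higher number here means a weaker inhibitor, a lower number a stronger inhibitor), compound 1 gives 4200 nM, while compound 2 gives 24900 nM. Within the data shown here, compound 2 therefore stands with the higher of the two numbers, set apart from compound 1 by the single measured step, a 5.9-fold higher number from compound 1 to compound 2 (0.77 log units; beyond the scatter).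

Compound 3 `COc1cc(-c2c(C#N)c(-c3cccs3)nc3c2c(-c2ccccc2)nn3-c2ccccc2)ccc1O` differs from compound 2 by thiophen-2-yl in place of furan-2-yl on an aromatic carbon. Among the measured compounds shown here, this exchange of one five-membered ring for another has not been measured here: the only known step concerns the methoxy group, a different part of the molecule, so it gives no direct guide. For the measured compounds named here, with no comparable step to lean on, the expected change is none beyond the scatter, estimated as a 1.1-fold lower number from compound 2 to compound 3 (0.05 log units; within the scatter). For compound 3 the expected value is 22000 nM, with a range from 7000 nM to 65000 nM.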

Compound 3, half-maximal inhibitory concentration: 15400 nM
Compound 3: the middle estimate sits 1.4-fold (0.15 log units) above what was measured; the range from low to high includes it.
By their numbers in this assay, from the lowest: compound 1; then compounds 3 and 2 (each within the scatter of the next).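

In this assay, placing thiophen-2-yl instead of furan-2-yl on the aromatic carbon next to the ring nitrogen gives a 1.6-fold lower number from compound 2 to compound 3 (0.21 log units; within the scatter), so at this position sulfur can stand in for oxygen in the five-membered ring without a change that can be told from the scatter. The earlier step, a 5.9-fold higher number from compound 1 to compound 2 (0.77 log units; beyond the scatter), concerned methoxy on a different part of the molecule and lay beyond the scatter, so it said nothing about this position. No outside measurement is available to explain why this exchange leaves the number within the scatter.

From the compounds shown here alone, both groups seen here are five-membered aromatic rings with one hetero atom, so the effect of something quite different at this position, such as a phenyl ring, an amine or a longer chain, remains open. Also open, going by these compounds, is whether the same exchange would behave alike on compound 1, which lacks the methoxy group.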